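Homologating the amide on a quinazoline piperidine

This account rests on a few compounds, and the source may have more. Where it says the series, first, only, none or still open, it means among the compounds named here.

Of the compounds shown here, three built on a shared core have been measured in an assay on isolated protein for displacement of a labelled ligand from Adrenergic receptor alpha-1 (Rattus norvegicus); on this read-out higher numbers stand for weaker inhibition and lower numbers for stronger inhibition. Compound 1 `CCCCNC(=O)C1CCCN(c2nc(N)c3cc(OC)c(OC)cc3n2)C1` gives 8.25 nM, compound 2 `COc1cc2nc(N3CCC(C(=O)NCCO)CC3)nc(N)c2cc1OC` gives 1.73 nM, and compound 3 `COCCNC(=O)C1CCN(c2nc(N)c3cc(OC)c(OC)cc3n2)CC1` gives 1.13 nM. Among the measured compounds shown here, compound 3 thus carries the lowest of the three numbers, though the one single step among them, a 1.5-fold lower number from compound 2 to compound 3 (0.18 log units; within the scatter), is within the scatter, while compound 1 sits clearly higher than compound 3, a gap beyond the scatter.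

Compound 4 `CCCCNC(=O)CCC1CCN(c2nc(N)c3cc(OC)c(OC)cc3n2)CC1` is not yet measured. It differs from compound 3 in one place: 2-(butylcarbamoyl)ethyl in place of (2-methoxyethyl)carbamoyl on a saturated ring carbon. For the measured compounds named here, no measured step covers this change directly. Going by the values given here, the only single step on record, a 1.5-fold lower number from compound 2 to compound 3 (0.18 log units; within the scatter), concerns a different part of the chain and is within the scatter. Compound 1, which also carries a butylamide but on another ring position, shows a higher number than compound 3, yet it differs in two places, so its value is only a loose pointer.

Given this, compound 4 is expected to show a modest rise, a 2.7-fold higher number from compound 3 to compound 4 (0.42 log units; beyond the scatter), in this assay. The estimate for compound 4 is 3 nM, with a range from 0.8 nM to 12 nM.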

Compound 4, inhibition constant: 0.47 nM
Compound 4: middle estimate off by 6.4-fold (0.81 log units), on the high side; the whole stated range lies above it.
By their numbers in this assay, from the lowest: compound 4; then compounds 3 and 2 (each within the scatter of the next); then compound 1.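

The position three ring bonds from the ring nitrogen clearly accepts a larger group without loss in this assay: replacing (2-methoxyethyl)carbamoyl with 2-(butylcarbamoyl)ethyl gives a 2.4-fold lower number from compound 3 to compound 4 (0.38 log units; beyond the scatter) and this modest gain exceeds the scatter. Compared with the alcohol-bearing chain, the same new group gives a 3.7-fold lower number from compound 2 to compound 4 (0.57 log units; beyond the scatter) and so the gain holds against both measured neighbours, whereas the earlier step between those two neighbours stayed within the scatter. Nothing in the data explains why the number falls.

The swap alters the chain on both sides of the amide at once, so the shares of the butyl end and of the ethyl link joining the amide to the ring remain unseparated. Butylcarbamoyl on this same ring carbon, or 2-[(2-methoxyethyl)carbamoyl]ethyl, would separate them, and a longer chain such as hexyl would show whether the trend continues.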